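The source may report more compounds than this note shows. Statements on the series, on what has been measured and on what is new or still open speak of the compounds shown alone.

In a functional assay on HepG2 cells (Homo sapiens) for cytotoxicity, read by MTT assay, with a stated time of 24 h (a higher number here means a weaker inhibitor, a lower number a stronger inhibitor), compound 3 `CN1C/C(=C\c2ccc(Br)cc2)C(=O)/C(=C/c2cccc([N+](=O)[O-])c2)C1` gives 8800 nM, a number clearly higher than that of compound 1 `CN1C/C(=C\c2ccc(C(F)(F)F)cc2)C(=O)/C(=C/c2ccccc2F)C1` at 4140 nM. Compound 2 `CN1C/C(=C\c2ccc(Cl)cc2)C(=O)/C(=C/c2cccc([N+](=O)[O-])c2)C1` gives 8210 nM, level with compound 3 within the scatter. Compound 4 `CN1C/C(=C\c2ccc(C(F)(F)F)cc2)C(=O)/C(=C/c2cccc([N+](=O)[O-])c2)C1` has trifluoromethyl in place of bromo on an aromatic carbon. For the measured compounds named here, the one measured step at this place, a 1.1-fold higher number from compound 2 to compound 3 (0.03 log units; within the scatter), exchanged chloro for bromo and stayed within the scatter. Going by the values given here, compound 1 also carries trifluoromethyl, but it differs elsewhere, so it gives no clean step. Little change is therefore expected in this assay, with an estimated 1.2-fold lower number from compound 3 to compound 4 (0.07 log units; within the scatter), which would lie within the scatter. Compound 4 is estimated at 7500 nM, with an expected range of 3500 nM to 15000 nM.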

Compound 4, half-maximal inhibitory concentration: 1040 nM
Compound 4: middle estimate off by 7.2-fold (0.86 log units), on the high side, and the stated range ends above it.
By their numbers in this assay, from the lowest: compound 4; then compounds 1, 2 and 3 (each within the scatter of the next, the first and the last beyond it).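

In this assay the exchange of chloro for bromo had left the number level, yet trifluoromethyl on this aromatic carbon stands apart, with an 8.5-fold lower number from compound 3 to compound 4 (0.93 log units; beyond the scatter) and a 7.9-fold lower number from compound 2 to compound 4 (0.90 log units; beyond the scatter) of similar size. This place therefore does respond to its group, even though the two halogens read alike. The other aryl group matters too: with trifluoromethyl held fixed, 3-nitrophenyl in place of 2-fluorophenyl gives a 4.0-fold lower number from compound 1 to compound 4 (0.60 log units; beyond the scatter) in the same direction.

Nothing measured here accounts for these gaps. Going by these compounds, how an amine or a carboxylic acid at this place would read remains open.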